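Octyl-linked benzamide: piperidine in place of phthalimide

The source may hold more compounds than are shown below. What is called first, only, known or untested is meant among the compounds shown, and "the series" means these compounds.

Measured so far:
compound 1, `CC(C)n1c(=O)n(C(=O)NC2CCNCC2)c2ccccc21`: 1580 nM
compound 2, `COc1cc(N)c(Cl)cc1C(=O)NC1CCN(CCCCCCCCN2C(=O)c3ccccc3C2=O)CC1`: 39.8 nM

In an assay on HEK293 cells for displacement of a labelled ligand from 5-hydroxytryptamine receptor 4 (Homo sapiens), read by scintillation counting (on this read-out higher numbers stand for weaker inhibition and lower numbers for stronger inhibition), compound 2 gives 39.8 nM, the lowest of the two numbers; compound 1 gives 1580 nM, a gap beyond the scatter. Compound 3, `COc1cc(N)c(Cl)cc1C(=O)NC1CCN(CCCCCCCCN2CCCCC2)CC1`, is not yet measured. It differs from compound 2 by a group of 6 heavy atoms (5 carbon, 1 nitrogen; one six-membered non-aromatic ring with 1 hetero atom) in place of a group of 11 heavy atoms (8 carbon, 1 nitrogen, 2 oxygen; one five-membered non-aromatic ring with 1 hetero atom, one six-membered aromatic ring of carbon only), on a saturated chain carbon, eight bonds along the chain from an amine nitrogen in a ring. Going by the values given here, no measured pair shows such a change here, so the direction is uncertain. A modest step from compound 2 to compound 3 of a 2.0-fold higher number from compound 2 to compound 3 (0.30 log units; within the scatter) toward weaker inhibition is expected. Compound 3 is estimated at 80 nM, with a range from 15 nM to 400 nM.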

Compound 3, inhibition constant: 3.16 nM
Beside the measured number, compound 3's estimate is 25-fold (1.40 log units) above it; the whole stated range lies above it.
By their numbers in this assay, from the lowest: compound 3; then compound 2; then compound 1.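

On the saturated chain carbon, eight bonds along the chain from an amine nitrogen in a ring, piperidin-1-yl in place of the phthalimide group gives a 13-fold lower number from compound 2 to compound 3 (1.10 log units; beyond the scatter) in this assay, so the group at this chain end strongly affects the number. The change removes both carbonyls and the aromatic ring at once, so this single step cannot separate their contributions. Nothing at hand explains the step. 

The compounds shown leave open whether another terminal amine, such as morpholine or pyrrolidine, would match piperidine. They also leave open how a shorter or longer chain would fare with piperidine at its end.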